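From acetoxy to ethoxy: working notes on compound 3

A few compounds are considered here, and "the series" means these few. Any claim that something is new, unique, unknown or untested is made for them only; others in the source may bear on it.

Of the compounds shown here, two have been read so far in a functional assay on AGS cells (Homo sapiens) for cytotoxicity, read by MTT assay; on this read-out higher numbers stand for weaker inhibition and lower numbers for stronger inhibition. Compound 1 `C=C[C@@](C)(/C=C/c1ccc(O)cc1)CCC(O)C(C)(C)O` reaches only a limit of the assay, > 50000 nM. Among the measured compounds shown here, compound 2 `C=C[C@@](C)(/C=C/c1ccc(OC(C)=O)cc1)CCC=C(C)C` gives 26800 nM, the one actual number available, and so serves as the reference point for the next compound.

Compound 3 `C=C[C@@](C)(/C=C/c1ccc(OCC)cc1)CCC=C(C)C` carries ethyl in place of acetyl on an oxygen on an aromatic ring, that is, acetoxy to ethoxy (ethyl in place of acetyl on an oxygen on an aromatic ring). For the measured compounds named here, no measured pair isolates this change, so the expectation rests on compound 2 at 26800 nM alone. No shift beyond the scatter is expected in this assay, and no direction can be favoured. The expected change is a 1.0-fold higher number from compound 2 to compound 3 (0.02 log units; within the scatter). For compound 3 the estimated value is 28000 nM, with an expected range of 13000 nM to 50000 nM.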

Compound 3, half-maximal inhibitory concentration: > 50000 nM
Compound 3 gave a limit, no number; the forecaster's own chance of this, stated with the estimate: 20%; middle value at least 1.7-fold (0.25 log units) from the limit.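

In this assay, among the compounds shown here, the change from acetoxy to ethoxy gives the first step that isolates this oxygen on the aromatic ring: it reads an at least 1.8-fold higher number from compound 2 to compound 3 (0.27 log units; that floor lies within the scatter) and so marks only a lower bound. Ethyl in place of acetyl brings no stronger inhibition here, and the carbonyl-bearing acetyl is not needed for compound 3 to stay in the same limited range of the read-out only in the sense that neither compound gives strong inhibition. The full size of the step cannot be read, since compound 3 gives a limit and not a number: the limit of > 50000 nM in this assay, at which 2 of the 3 values shown sit.

Going by these compounds, whether the true gap between acetoxy and ethoxy lies beyond the scatter stays open. Also open, on these data alone, is how a methoxy, a longer chain or an amine on this oxygen would read against compound 2.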